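Pyridin-4-yl in place of 4-fluorophenyl: series notes

The source may report more compounds than this note shows. Statements on the series, on what has been measured and on what is new or still open speak of the compounds shown alone.

Measured in a functional assay on MCF7 cells (Homo sapiens) for antiproliferative activity, with a stated time of 5 days; a higher number here means a weaker inhibitor, a lower number a stronger inhibitor:
- compound 1 `COc1ccc(-c2[nH]c3ccc(C)cc3c2C=O)cc1` gives 140 nM
- compound 2 `CCCCc1ccc2[nH]c(-c3ccc(OC)cc3)c(/C=N/NC(=O)c3ccc(F)cc3)c2c1` gives 84 nM
- compound 3 `CCCCc1ccc2[nH]c(-c3ccc(C(F)(F)F)cc3)c(/C=N/NC(=O)c3ccc(OC)cc3)c2c1` gives 618 nM

Compound 2 and compound 1 lie within the scatter of each other, so these two values cannot be separated. Compound 3 has a higher number than compound 2, and that gap lies beyond the scatter.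

The next compound to be tested is compound 4 `CCCCc1ccc2[nH]c(-c3ccc(OC)cc3)c(/C=N/NC(=O)c3ccncc3)c2c1`, which carries pyridin-4-yl in place of 4-fluorophenyl on a carbonyl carbon.

Among the compounds with values here, no measured pair shows this change on its own, and the three values give no direct guide to its size or direction in this assay. A small change toward a higher number is expected, and the estimated 1.8-fold higher number from compound 2 to compound 4 (0.25 log units; within the scatter) stays within the scatter. The range is kept wide, and its upper end reaches the region of compound 3 at 618 nM. For compound 4 the estimated value is 150 nM, with an expected range of 50 nM to 450 nM.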

Compound 4, half-maximal inhibitory concentration: 69 nM
Beside the measured number, compound 4's estimate is 2.2-fold (0.34 log units) above it; low and high end bracket the measured number.
By their numbers in this assay, from the lowest: compounds 4, 2 and 1 (each within the scatter of the next, the first and the last beyond it); then compound 3.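

In this assay, pyridin-4-yl in place of 4-fluorophenyl on a carbonyl carbon gives a 1.2-fold lower number from compound 2 to compound 4 (0.09 log units; within the scatter), so the two values cannot be separated. Within the data shown here, this is the first direct reading at this position: a six-membered aromatic ring with one hetero atom and one hydrogen-bond acceptor takes the place of a carbon-only ring bearing fluorine, and the value stays within the scatter. Nothing measured here speaks to the reason for this result.

Open, on these data alone, is whether this position also accepts groups that are not six-membered aromatic rings, such as a cyclohexyl ring, a morpholine or a longer alkyl chain. Also open, as far as these compounds go, is whether the same replacement gives a like result on the core of compound 3, which carries trifluoromethyl.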